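The compounds below may be only part of what the source reports. "The series", "measured", "known", "first", "only" and "open" are said of these compounds alone.

Compound 1 `O=C(Nc1cccc(-n2cc(-c3ccncc3)c(-c3cc(O)cc(Cl)c3)n2)c1)Nc1ccc(Cl)c(C(F)(F)F)c1` is the reference for this account. Among the measured compounds shown here, in a functional assay on OVCAR-3 cells (Homo sapiens) for inhibition, read by sulforhodamine B assay, with a stated time of 48 h, tested at 0.01 uM (a lower number here means a stronger effect, a higher number a weaker effect of the compound at the concentration tested), compound 1 gives 101%, the lowest of the two numbers so far; its nearest neighbour is compound 2 `O=C(Nc1cccc(-n2cc(-c3ccncc3)c(-c3cc(O)cc(Cl)c3)n2)c1)Nc1ccc(Cl)c(Cl)c1`, which in this assay gives 103%. For the measured compounds named here, the only measured step, a number 2 percentage points higher from compound 1 to compound 2 (within the scatter), comes with chloro in place of trifluoromethyl on an aromatic carbon and lies within the scatter. The unmeasured compound 3 `COc1cc(Cl)cc(-c2nn(-c3cccc(NC(=O)Nc4ccc(Cl)c(C(F)(F)F)c4)c3)cc2-c2ccncc2)c1` differs from compound 1 by methyl in place of hydrogen on an oxygen on an aromatic ring. Going by the values given here, no measured step touches the hydroxy of compound 1, so nothing recorded bears directly on this change; the one recorded step, small as it is, shows that a change elsewhere on the shared core left this assay flat. For compound 3 the estimate is therefore a step of a number 1 percentage points lower from compound 1 to compound 3 (within the scatter), no movement beyond the scatter expected. Compound 3 is expected to give 100% in this assay, within 88% to 112%.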

Compound 3, a percentage reported as activity, at one concentration (the size of the read-out at that concentration, not a potency): 91%
Compound 3: middle estimate off by 9 percentage points, on the high side; measured number inside the range.
By their numbers in this assay, from the lowest: compounds 3, 1 and 2 (each within the scatter of the next, the first and the last beyond it).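

In this assay, among the compounds shown here, the change from hydroxy to methoxy on the 3-chloro-5-hydroxyphenyl group gives a number 10 percentage points lower from compound 1 to compound 3 (within the scatter), the first measured change at this oxygen, so adding a methyl there moves the number no further than the scatter at this one concentration. The other step from compound 1, a number 2 percentage points higher from compound 1 to compound 2 (within the scatter), also stays within the scatter, so neither of the two changes measured on compound 1 gives a clear shift in this assay. No supporting data are available to explain the step from hydroxy to methoxy.

The compounds shown leave open whether an ethyl group or a longer chain on this oxygen, or an amine in place of the hydroxy, would move the number beyond the scatter. They also leave open whether hydroxy and methoxy would separate at a higher concentration.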